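From methoxy to trifluoromethoxy in an antiproliferative series

The source may report more compounds than this note shows. Statements on the series, on what has been measured and on what is new or still open speak of the compounds shown alone.

Of the compounds shown here, three sharing one core have been measured in a functional assay on SK-OV-3 cells (Homo sapiens) for antiproliferative activity, read by MTT assay, with a stated time of 72 h; a higher number here means a weaker inhibitor, a lower number a stronger inhibitor. Compound 1 `O=C(CCc1cccc2c1B(O)OC2)Nc1cccc(-c2ccccc2)c1` gives 250 nM, compound 2 `O=C(CCc1cccc2c1B(O)OC2)Nc1cccc(-c2ccc(F)cc2)c1` gives 93 nM, and compound 3 `COc1ccc(-c2cccc(NC(=O)CCc3cccc4c3B(O)OC4)c2)cc1` gives 48 nM. Compound 3 holds the lowest of these numbers, yet its nearest neighbour cannot be separated from it: the record shows a 1.9-fold lower number from compound 2 to compound 3 (0.29 log units; within the scatter). Only the distance to the unsubstituted compound is clear, with a 5.2-fold lower number from compound 1 to compound 3 (0.72 log units; beyond the scatter), alongside a 2.7-fold lower number from compound 1 to compound 2 (0.43 log units; beyond the scatter).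

Compound 4 `O=C(CCc1cccc2c1B(O)OC2)Nc1cccc(-c2ccc(OC(F)(F)F)cc2)c1` keeps the core and alters one group: trifluoromethyl in place of methyl on an oxygen on an aromatic ring. In words, this is trifluoromethyl in place of methyl on an oxygen on an aromatic ring, or methoxy to trifluoromethoxy. Among the compounds with values here, no measured step makes this exact change. The closest guide is the exchange of fluoro for methoxy, which stayed within the scatter, while both substituents gave modest steps away from hydrogen. On that basis, a modest gain over hydrogen is expected to survive, and no step beyond the scatter is expected from the new group. The expected step, a small rise, is a 1.7-fold higher number from compound 3 to compound 4 (0.22 log units; within the scatter). Compound 4 is estimated at 80 nM, with an expected range of 30 nM to 220 nM.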

Compound 4, half-maximal inhibitory concentration: 560 nM
The estimate for compound 4 lay 7.0-fold (0.85 log units) below the measured number; the whole stated range lies below it.
By their numbers in this assay, from the lowest: compounds 3 and 2 (each within the scatter of the next); then compound 1; then compound 4.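

In this assay, the oxygen on the aromatic ring stays in place and only the methyl on it gives way to trifluoromethyl, yet this single exchange produces the largest step in the series (a 12-fold higher number from compound 3 to compound 4 (1.07 log units; beyond the scatter)), so the group carried on that oxygen strongly affects the result. Compound 4 also separates from the fluoro compound (a 6.0-fold higher number from compound 2 to compound 4 (0.78 log units; beyond the scatter)) and, unlike the fluoro and methoxy compounds, lies on the higher side of the unsubstituted compound (a 2.2-fold higher number from compound 1 to compound 4 (0.35 log units; beyond the scatter)), which shows that substitution at this place does not always lower the number relative to hydrogen. Nothing available explains this reversal.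

The compounds shown leave open whether the rise requires all three fluorines, which an ethyl or a difluoromethyl on the same oxygen would help to test. They also leave open whether the oxygen contributes to the effect, a question that a trifluoromethyl placed directly on the aromatic carbon, or an amine or a hydroxyl at that carbon, could begin to address.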